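Triazole substituent series: cytotoxicity notes toward compound 4

The source may report more compounds than this note shows. Statements on the series, on what has been measured and on what is new or still open speak of the compounds shown alone.

Three compounds on one shared core have been run in an ADME assay on HEK293 cells (Homo sapiens) for cytotoxicity, read by sulforhodamine B assay, with a stated time of 48 h, tested at 10 uM; on this read-out higher numbers stand for more inhibition at the one concentration tested (going by the name of the read-out) and lower numbers for less inhibition.

Compound 1 `COc1nc2ccc(Br)cc2cc1C(c1ccccc1)n1cc(-c2cccc(F)c2)nn1` gives 6.84%.
Compound 2 `COc1nc2ccc(Br)cc2cc1C(c1ccccc1)n1cc(CCCCCO)nn1` gives 7.96%.
Compound 3 `CCCCCCc1cn(C(c2ccccc2)c2cc3cc(Br)ccc3nc2OC)nn1` gives -3.17%.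

Compound 3 stands lowest of the three numbers on this assay: a number 10 percentage points lower from compound 1 to compound 3 (within the scatter), and a number 11.1 percentage points lower from compound 2 to compound 3 (beyond the scatter). Only the gap to compound 2 lies beyond the scatter, so the number for compound 3 cannot be called lower than that of compound 1. Among the two that carry a chain, a number 1.1 percentage points higher from compound 1 to compound 2 (within the scatter), so the 3-fluorophenyl and 5-hydroxypentyl analogues are indistinguishable here.

Compound 4 `COc1nc2ccc(Br)cc2cc1C(c1ccccc1)n1cc(-c2ccc(F)cc2)nn1` has not yet been measured. It differs from compound 3 as follows: 4-fluorophenyl in place of hexyl on an aromatic carbon. The step that bears on this change most directly is a number 10 percentage points lower from compound 1 to compound 3 (within the scatter), which removed a fluorophenyl group and put hexyl in its place; compound 4 reverses that exchange, with 4-fluorophenyl rather than 3-fluorophenyl. Since that step was within the scatter, the return step is expected to be small as well, trending upward toward the value of compound 1 but not reliably beyond noise. The expected step is a number 8.2 percentage points higher from compound 3 to compound 4 (within the scatter). Compound 4 is therefore estimated at 5%, with a range from -8% to 18%.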

Compound 4, a percentage reported as inhibition, at one concentration (the size of the read-out at that concentration, not a potency): 4.04%
The estimate for compound 4 lay 1 percentage points above the measured number, within the range that was stated.
By their numbers in this assay, from the lowest: compounds 3, 4, 1 and 2 (each within the scatter of the next, the first and the last beyond it).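

Exchanging 3-fluorophenyl for 4-fluorophenyl on this aromatic carbon of the five-membered ring gives no readable difference in this assay (a number 2.8 percentage points lower from compound 1 to compound 4 (within the scatter)), so these two fluorophenyl groups cannot be told apart here. The 4-fluorophenyl group also cannot be separated from either open chain, hexyl (a number 7.2 percentage points higher from compound 3 to compound 4 (within the scatter)) or 5-hydroxypentyl (a number 3.9 percentage points lower from compound 2 to compound 4 (within the scatter)), so at this position compound 4 shows no readable difference between an aromatic ring and either chain. Compound 4 adds no further gap beyond the scatter, and the only such gap among the four compounds remains the one between the two chains (a number 11.1 percentage points lower from compound 2 to compound 3 (beyond the scatter)), which on its own is too thin a basis for a trend at this position.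

Still open, on these data alone, is whether an amine, a carboxylic acid or a chain longer than hexyl on this aromatic carbon would move the number beyond the scatter from compound 4, and whether replacing the bromine on the shared core would do so. Nothing available here gives a reason for the one gap that can be read.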